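This account rests on a few compounds, and the source may have more. Where it says the series, first, only, none or still open, it means among the compounds named here.

Working notes on the series.

Of the compounds shown here, three sharing one core have been measured, differing only in the group on the amide-type nitrogen of the oxamide. Compound 1 `C[C@H](NC(=O)C(=O)NC1CCCCC1)C(=O)N[C@@H](CC(=O)O)C(=O)COc1c(F)c(F)cc(F)c1F` carries a cyclohexyl group, and in a functional assay on Jurkat cells (Homo sapiens) for inhibition (on this read-out higher numbers stand for weaker inhibition and lower numbers for stronger inhibition), compound 1 gives 150 nM. Compound 2 `C[C@H](NC(=O)C(=O)NCc1ccccc1)C(=O)N[C@@H](CC(=O)O)C(=O)COc1c(F)c(F)cc(F)c1F` carries a benzyl group; in this assay compound 2 gives 300 nM. Compound 3 `C[C@H](NC(=O)C(=O)Nc1ccccc1Br)C(=O)N[C@@H](CC(=O)O)C(=O)COc1c(F)c(F)cc(F)c1F` carries a 2-bromophenyl group; in this assay compound 3 gives 75 nM, the lowest of the three numbers, though one gap is a 2.0-fold lower number from compound 1 to compound 3 (0.30 log units; within the scatter), and the other gap is a 4.0-fold lower number from compound 2 to compound 3 (0.60 log units; beyond the scatter). The benzyl-for-cyclohexyl exchange, a 2.0-fold higher number from compound 1 to compound 2 (0.30 log units; within the scatter), stays within the scatter.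

Compound 4 `C[C@H](NC(=O)C(=O)Nc1ccccc1Oc1ccccc1)C(=O)N[C@@H](CC(=O)O)C(=O)COc1c(F)c(F)cc(F)c1F` is not yet measured. It differs from compound 3 by phenoxy in place of bromo on an aromatic carbon. Within the data shown here, none of the measured steps alters a substituent on the aromatic ring of compound 3; the steps from compound 1 and compound 2 to compound 3 exchange the whole group on the nitrogen, and their sizes, a 2.0-fold lower number from compound 1 to compound 3 (0.30 log units; within the scatter) and a 4.0-fold lower number from compound 2 to compound 3 (0.60 log units; beyond the scatter), remain modest. On that basis no step beyond the scatter is expected for compound 4 in this assay, the expected step being a 1.2-fold higher number from compound 3 to compound 4 (0.08 log units; within the scatter). The estimate for compound 4 in this assay is 90 nM, with a range from 30 nM to 270 nM.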

Compound 4, half-maximal inhibitory concentration: 530 nM
Beside the measured number, compound 4's estimate is 5.9-fold (0.77 log units) below it; measured number outside the range, above it.
By their numbers in this assay, from the lowest: compounds 3, 1, 2 and 4 (each within the scatter of the next, the first and the last beyond it).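

The step of a 7.1-fold higher number from compound 3 to compound 4 (0.85 log units; beyond the scatter) in this assay is the first one shown that leaves the group on the amide-type nitrogen an aryl group and changes only a substituent on its ring, so this aromatic carbon, ortho to a large group, is not indifferent to what it carries. Among these compounds, the only earlier step beyond the scatter, a 4.0-fold lower number from compound 2 to compound 3 (0.60 log units; beyond the scatter), exchanged the whole group on the nitrogen, whereas here bromo, a single heavy atom, gives way to phenoxy, with its seven heavy atoms, one hydrogen-bond acceptor and an added six-membered aromatic ring, and the number moves upward. Nothing available bears on the cause of this step.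

The compounds shown leave open whether the step follows the oxygen atom, the added ring or both, which a methoxy group and a directly attached phenyl group on this carbon would help to separate. They also leave open what bromo itself contributes, which a chloro group or a plain hydrogen in its place would show.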